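This account rests on a few compounds, and the source may have more. Where it says the series, first, only, none or still open, it means among the compounds named here.

Three compounds built on one shared core were tested in an ADME assay on HEK293-A cells (Homo sapiens) for cytotoxicity, read by MTT assay, with a stated time of 48 h; a lower number here means a stronger inhibitor, a higher number a weaker inhibitor. Compound 1 `O=C1CCC(=O)N1C[C@H]1CN(c2ccc(-n3cc(-c4ccccn4)cn3)c(F)c2)C(=O)O1` returns only a limit of the assay, > 400 ug/mL. Compound 3 `O=C1O[C@@H](CNC(=O)C(F)(F)F)CN1c1ccc(-n2cc(-c3ccccn3)cn2)c(F)c1` likewise returns only a limit, > 400 ug/mL. Within the data shown here, compound 2 `O=C1CSC(=O)N1C[C@H]1CN(c2ccc(-n3cc(-c4ccccn4)cn3)c(F)c2)C(=O)O1` is the one compound with an actual number, 283 ug/mL, and so it is the only fixed point among the three. The two measured steps that touch compound 2 are both small: an at least 1.4-fold lower number from compound 1 to compound 2 (0.15 log units; that floor lies within the scatter), and an at least 1.4-fold higher number from compound 2 to compound 3 (0.15 log units; that floor lies within the scatter), each a floor that lies within the scatter. Both exchanges sit on the saturated chain carbon bound to a saturated ring carbon, and neither moves the reading beyond what repeated measurements would show on their own.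

Compound 4 `CONC(=O)[C@H]1CN(c2ccc(-n3cc(-c4ccccn4)cn3)c(F)c2)C(=O)O1` has not yet been measured. Relative to compound 2 the change is methoxycarbamoyl in place of (2,4-dioxo-1,3-thiazolidin-3-yl)methyl on a saturated ring carbon. Among the measured compounds shown here, this exchange is made on the ring itself rather than on the chain, so no measured step matches it exactly; the nearest guide is the pair of small steps around compound 2, with the limit of > 400 ug/mL in this assay, at which 2 of the 3 values shown sit, marking where most readings rest. Compound 4 is therefore expected to give a number close to compound 2, or again only a limit. The step of a 1.2-fold higher number from compound 2 to compound 4 (0.07 log units; within the scatter) is expected to stay within the scatter. The estimate for compound 4 is 330 ug/mL, between 150 ug/mL and 400 ug/mL.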

Compound 4, half-maximal inhibitory concentration: > 400 ug/mL
Compound 4 was reported as a limit; the forecaster's own chance of this, stated with the estimate: 50%; middle value at least 1.2-fold (0.08 log units) away from the limit.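

Putting methoxycarbamoyl in place of (2,4-dioxo-1,3-thiazolidin-3-yl)methyl on the saturated ring carbon removes the five-membered ring and adds a hydrogen-bond donor, and it gives an at least 1.4-fold higher number from compound 2 to compound 4 (0.15 log units; that floor lies within the scatter). Compounds 1, 2 and 3 all carry their variable group through a saturated chain carbon, whereas compound 4 has no such carbon, so a change in how the group is attached can also leave the reading at the limit of the assay. The steps from compound 3 and from compound 1 to compound 4 cannot be read because both ends of each are limits, and the set now rests largely at one reading: the limit of > 400 ug/mL in this assay, at which 3 of the 4 values shown sit.

As far as these compounds go, a limit gives no actual number, so the true size of the step from compound 2 remains unknown, and that step's floor does not separate the two compounds beyond the scatter. From the compounds shown here alone, whether an amine or a carboxylic acid on this ring carbon, or a longer chain ending in the 2,4-dioxo-1,3-thiazolidin-3-yl group, would give a clearly lower number than compound 2 stays open.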